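This account rests on a few compounds, and the source may have more. Where it says the series, first, only, none or still open, it means among the compounds named here.

Measured compounds:
compound 1, `Cc1nc(N)sc1CCCN/C(N)=N/C(=O)NCC(C)CCc1ccccc1`: 0.2
compound 2, `Cc1nc(N)sc1CCCN/C(N)=N/C(=O)NCC(C)C1CCCCC1`: 0.4
compound 3, `Cc1nc(N)sc1CCCN/C(N)=N/C(=O)NCC(C)CC1CCCCC1`: 0.22

In a functional assay on HEK293T cells for agonist activity at histamine H2 receptor (Homo sapiens), read by beta-arrestin recruitment (a higher number here means a larger maximal response, a lower number a smaller maximal response), compound 3 is second highest of the three: its nearest neighbour is compound 1, which reads a number 0.020 higher from compound 1 to compound 3 (within the scatter); the step a number 0.18 lower from compound 2 to compound 3 (beyond the scatter) separates it from compound 2. Compound 4, `Cc1ccc(CC(C)CNC(=O)/N=C(\N)NCCCc2sc(N)nc2C)cc1`, differs from compound 3 as follows: 4-methylphenyl in place of cyclohexyl on a saturated chain carbon, three bonds along the chain from an amide-type nitrogen. The step bearing most directly on this is a number 0.020 higher from compound 1 to compound 3 (within the scatter), which swapped a saturated ring for an aromatic one at the same place and stayed within the scatter. The larger steps a number 0.20 higher from compound 1 to compound 2 (beyond the scatter) and a number 0.18 lower from compound 2 to compound 3 (beyond the scatter) concern a different place. Compound 4 is therefore expected to show no change beyond the scatter, no change at the digits printed from compound 3 to compound 4 (within the scatter), in this assay. The estimate for compound 4 in this assay is 0.22, between 0.12 and 0.35.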

Compound 4, intrinsic activity: the largest response reached, as a fraction of the reference agonist's: 0.1
Compound 4: middle estimate off by 0.12, on the high side, outside the stated range (below it).
By their numbers in this assay, from the lowest: compounds 4, 1 and 3 (each within the scatter of the next, the first and the last beyond it); then compound 2.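

In this assay the change from cyclohexyl to 4-methylphenyl on a saturated chain carbon, three bonds along the chain from an amide-type nitrogen, is not neutral: a number 0.12 lower from compound 3 to compound 4 (beyond the scatter) shows that a swap of a saturated ring for an aromatic one can matter here. Compound 4 still stays level with the benzyl-bearing compound 1, with a number 0.10 lower from compound 1 to compound 4 (within the scatter) as the printed step. The gap to the best reader of the set is wider, with a number 0.30 lower from compound 2 to compound 4 (beyond the scatter) as the largest step shown.

As far as these compounds go, whether plain phenyl at this place would read with compound 3 or with compound 4 remains open, which leaves the share of the ring and of its methyl unresolved. Nothing shown offers a reason for these steps.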